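A few compounds are considered here, and "the series" means these few. Any claim that something is new, unique, unknown or untested is made for them only; others in the source may bear on it.

Series notes, step from compound 3 to compound 4. The three measured compounds, compound 1 `Nc1ccccc1NC(=O)c1ccc(CSC(=S)N2CCN(Cc3ccccn3)CC2)cc1`, compound 2 `Cc1ccc(N2CCN(C(=S)SCc3ccc(C(=O)Nc4ccccc4N)cc3)CC2)cc1` and compound 3 `CN1CCN(C(=S)SCc2ccc(C(=O)Nc3ccccc3N)cc2)CC1`, share one core and differ only at the amine nitrogen in a ring. In a functional assay on MGC-803 cells (Homo sapiens) for antiproliferative activity, read by CCK-8 assay, with a stated time of 72 h, tested at 2 uM (on this read-out higher numbers stand for a stronger effect at the one concentration tested and lower numbers for a weaker effect), compound 1 gives 23.4%, compound 2 gives 33.4% and compound 3 gives 29.6%. Compound 3 stands second highest of the three; all three numbers lie within the scatter of one another, so no order can be read from them. The steps of a number 10 percentage points higher from compound 1 to compound 2 (within the scatter), a number 6.2 percentage points higher from compound 1 to compound 3 (within the scatter) and a number 3.8 percentage points lower from compound 2 to compound 3 (within the scatter) are all within the scatter.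

Compound 4 `Nc1ccccc1NC(=O)c1ccc(CSC(=S)N2CCN(c3ccccc3F)CC2)cc1` differs from compound 3 by 2-fluorophenyl in place of methyl on an amine nitrogen in a ring. Among the compounds with values here, the step bearing most directly on it is the one from compound 2 to compound 3, an aryl group exchanged for methyl, which moved the number by a number 3.8 percentage points lower from compound 2 to compound 3 (within the scatter); the reverse exchange here is therefore expected to move the number by little, if at all. Within the data shown here, no measured step exceeded the scatter, so no step beyond the scatter is expected in this assay.

For compound 4 the expected step is a number 2.4 percentage points higher from compound 3 to compound 4 (within the scatter). Compound 4 is estimated at 32%, with a range from 22% to 43%.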

Compound 4, a percentage reported as inhibition, at one concentration (the size of the read-out at that concentration, not a potency): 33.7%
For compound 4 the middle estimate is 1.7 percentage points below the measured one; low and high end bracket the measured number.
By their numbers in this assay, from the lowest: compounds 1, 3, 2 and 4 (each within the scatter of the next, the first and the last beyond it).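

In this assay, within the data shown here, the pair formed by compound 1 and compound 4 is the first to pass the scatter (a number 10.3 percentage points higher from compound 1 to compound 4 (beyond the scatter)), and only modestly, so this position shows a first readable difference, between (pyridin-2-yl)methyl and 2-fluorophenyl on the amine nitrogen in a ring. The other two exchanges stay unresolved (a number 0.3 percentage points higher from compound 2 to compound 4 (within the scatter); a number 4.1 percentage points higher from compound 3 to compound 4 (within the scatter)), so neither 2-fluorophenyl against 4-methylphenyl nor 2-fluorophenyl against methyl separates at this concentration. Nothing available explains any of these steps.

From the compounds shown here alone, it remains open whether the difference from compound 1 goes with the linking carbon of (pyridin-2-yl)methyl or with its pyridine ring. A benzyl group or a longer alkyl chain on this nitrogen would help to separate those two parts.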